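Trimming an indolylmethyl from a hydroxamate amine linker

The compounds below may be only part of what the source reports. "The series", "measured", "known", "first", "only" and "open" are said of these compounds alone.

Two hydroxamic acids have been assayed so far in an assay on cells for inhibition of histone deacetylase 8 (Homo sapiens), read by fluorescence, with a stated time of 24 h; on this read-out lower numbers stand for stronger inhibition and higher numbers for weaker inhibition. Compound 1, `O=C(CCCCCCN(Cc1cc2ccccc2[nH]1)Cc1cc2ccccc2[nH]1)NO`, carries two (1H-indol-2-yl)methyl groups on its amine nitrogen and in this assay gives 4600 nM, the highest of the two numbers recorded. Compound 2, `Cc1cc(CNCCCCCCC(=O)NO)ccc1F`, a secondary amine with a single arylmethyl substituent, gives 2800 nM in this assay; the gap to compound 1 lies within the usual scatter, so no order between the two can be claimed.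

Compound 3, `O=C(CCCCCCNCc1cc2ccccc2[nH]1)NO`, has not yet been measured. It differs from compound 1 in one place: hydrogen in place of (1H-indol-2-yl)methyl on an amine nitrogen. The amine nitrogen of compound 3 is thus secondary, as in compound 2.

Because compound 2 shows 2800 nM with a secondary amine, compound 3 is expected to land near that level, with an estimated step of a 1.8-fold lower number from compound 1 to compound 3 (0.26 log units; within the scatter) that is small and not clearly beyond the scatter. Compound 3 is expected to give about 2500 nM in this assay, with a plausible range from 800 nM to 8000 nM.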

Compound 3, half-maximal inhibitory concentration: 620 nM
The estimate for compound 3 lay 4.0-fold (0.61 log units) above the measured number; measured number outside the range, below it.
By their numbers in this assay, from the lowest: compound 3; then compounds 2 and 1 (each within the scatter of the next).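

In this assay, taking one (1H-indol-2-yl)methyl off the amine nitrogen gives a 7.4-fold lower number from compound 1 to compound 3 (0.87 log units; beyond the scatter), so this change produces a difference that the scatter cannot account for, which the gap between the two earlier compounds could not show. At this position, the second (1H-indol-2-yl)methyl is therefore not needed for inhibition on this read-out, and the secondary amine of compound 3 outperforms the tertiary amine of compound 1. Nothing measured here explains why the change has this effect.

On these data alone, it remains open whether a smaller group such as methyl in place of the hydrogen would hold this level, or whether a primary amine, with the remaining (1H-indol-2-yl)methyl also gone, would do so. Also open, as far as these compounds go, is how a longer chain in the linker of compound 3 would shift its number.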